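A few compounds are considered here, and "the series" means these few. Any claim that something is new, unique, unknown or untested is made for them only; others in the source may bear on it.

Working notes on the series. Compound 1, structure `O=S(=O)(/C=C/c1ccc(Cl)c(Cl)c1)Cc1ccc(Nc2ncnc3ccccc23)cc1`, is the weaker of the two measured compounds: in a functional assay on OVCAR-8 cells (Homo sapiens) (on this read-out higher numbers stand for weaker inhibition of growth and lower numbers for stronger inhibition of growth), compound 1 gives 14000 nM, the highest of the two numbers seen so far. Its nearest neighbour is compound 2, structure `CC(C)(C)c1cc(/C=C/S(=O)(=O)Cc2ccc(Nc3ncnc4ccccc34)cc2)cc(C(C)(C)C)c1O`, which in this assay gives 5000 nM, a gap that lies beyond the scatter of the measurement. Among the measured compounds shown here, no pair of measured compounds differs in only one place, so no single-change step is available to lean on.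

Compound 3, structure `O=S(=O)(/C=C/c1ccc(O)cc1)Cc1ccc(Nc2ncnc3ccccc23)cc1`, is not yet measured. Relative to compound 1 the change is 4-hydroxyphenyl in place of 3,4-dichlorophenyl on a double-bonded chain carbon bound to a double-bonded chain carbon. The ring that leaves carries no hydrogen-bond donor or acceptor; the ring that enters carries one of each.

For the measured compounds named here, with only two measured points and no comparable step in hand, the expectation for compound 3 in this assay rests on compound 2 being the stronger of the pair at 5000 nM; the step from compound 1 to compound 3 is estimated at a 1.8-fold lower number from compound 1 to compound 3 (0.24 log units; within the scatter), toward a lower number but not far beyond the scatter. Compound 3 is therefore estimated at 8000 nM, with a likely range from 3000 nM to 25000 nM.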

Compound 3, concentration for 50% growth inhibition: 1000 nM
Compound 3: the middle estimate sits 8.0-fold (0.90 log units) above what was measured; the measured number lies below the stated range.
By their numbers in this assay, from the lowest: compound 3; then compound 2; then compound 1.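

In this assay, putting 4-hydroxyphenyl in place of 3,4-dichlorophenyl on a double-bonded chain carbon bound to a double-bonded chain carbon produces a 14-fold lower number from compound 1 to compound 3 (1.15 log units; beyond the scatter) and so gives the series its first single-change step, a large one that lies beyond the scatter. It shows that growth inhibition in this read-out is sensitive to the aromatic group at this place: with the rest of the structure held constant, the ring without a hydrogen-bond donor or acceptor gives way to one carrying one of each, and the number falls. No measurement on these groups is available to account for the size of this step.

The step removes both chlorine atoms and introduces the hydroxy group in a single change, so the compounds shown leave open whether the stronger inhibition follows the loss of the chlorine atoms, the arrival of the hydroxy group, or both together. On these data alone, it also remains open whether a methoxy group or an amine in place of the hydroxy group would keep the lower number.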